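The source may hold more compounds than are shown below. What is called first, only, known or untested is meant among the compounds shown, and "the series" means these compounds.

Compound 1 `COc1ccc(-c2cncnc2-c2cc(OC)c(OC)c(OC)c2)cc1Cl`: 1330 nM
Compound 2 `COc1cc(-c2ncncc2-c2ccc(OC(C)C)cc2)cc(OC)c1OC`: 9970 nM

In a functional assay on SiHa cells (Homo sapiens) for antiproliferative activity, read by CCK-8 assay, with a stated time of 72 h (a higher number here means a weaker inhibitor, a lower number a stronger inhibitor), compound 1 gives 1330 nM, the lowest of the two numbers shown. Compound 2 gives 9970 nM, a gap beyond the usual scatter. Compound 3 `COc1cc(-c2ncncc2-c2ccc(B(O)O)cc2)cc(OC)c1OC` has not yet been measured. It differs from compound 1 in one place: a group of 9 heavy atoms (6 carbon, 1 boron, 2 oxygen; one six-membered aromatic ring of carbon only) in place of a group of 9 heavy atoms (7 carbon, 1 oxygen, 1 chlorine; one six-membered aromatic ring of carbon only), on an aromatic carbon. Among the measured compounds shown here, no step between two measured compounds matches this change, so its size is uncertain. The number for compound 3 is expected to rise, by a 3.8-fold higher number from compound 1 to compound 3 (0.58 log units; beyond the scatter). Compound 3 is thus estimated at 5000 nM, with a likely range from 1500 nM to 20000 nM.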

Compound 3, half-maximal inhibitory concentration: 17500 nM
Compound 3: the middle estimate sits 3.5-fold (0.54 log units) below what was measured; the measured number falls inside the stated range.
By their numbers in this assay, from the lowest: compound 1; then compounds 2 and 3 (each within the scatter of the next).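

At this aromatic carbon, trading the 3-chloro-4-methoxyphenyl group for a phenyl ring carrying a boronic acid gives a large loss in this assay (a 13-fold higher number from compound 1 to compound 3 (1.12 log units; beyond the scatter)). Putting that boronic acid in place of the isopropoxy group of compound 2 gives a step within the scatter (a 1.8-fold higher number from compound 2 to compound 3 (0.24 log units; within the scatter)), so these two groups cannot be told apart here. No measurement at hand explains either step. Still open, from the compounds shown here alone, is whether the chlorine or the methoxy of compound 1 matters more, and how an amine or a carboxylic acid would read on that ring.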